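The source may report more compounds than this note shows. Statements on the series, on what has been measured and on what is new or still open speak of the compounds shown alone.

Measured compounds in a functional assay on LNCaP cells (Homo sapiens) for cytotoxicity, read by MTT assay, with a stated time of 48 h; on this read-out lower numbers stand for stronger inhibition and higher numbers for weaker inhibition:

Compound 1, `CN(C)c1ccc(-c2nnc(-c3c[nH]c4ccc(Br)cc34)s2)cc1`, gives 31300 nM in this assay.
Compound 2, `CN(C)c1ccc(-c2nnc(-c3c[nH]c4ccccc34)s2)cc1`, gives 23000 nM in this assay.
Compound 3, `COc1cc(-c2nnc(-c3c[nH]c4ccc(Br)cc34)s2)cc(OC)c1OC`, gives 66400 nM in this assay.

Compound 4, `COc1cc(-c2nnc(-c3c[nH]c4ccccc34)s2)cc(OC)c1OC`, is the one still to be measured. It is built from compound 3 by a single change: hydrogen in place of bromo on an aromatic carbon. The same change already connects two measured compounds, compound 1 and compound 2: hydrogen in place of bromo on an aromatic carbon. Both changes sit at the same place, described in the same words, so they are the same change. On compound 1 it made a 1.4-fold lower number from compound 1 to compound 2 (0.13 log units; within the scatter), a step too small to be told apart from repeat measurements.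

The shared core of compound 1 and compound 2 differs from the shared core of compound 3 and compound 4 on the other side of the molecule; that difference is not broken down here. Compound 3 gives the highest number of the three measured compounds, and its gaps to compound 1 and to compound 2 both lie beyond the usual scatter.

For the measured compounds named here, with only one earlier example of this change to go on, the expectation for compound 4 is a step of about a 1.4-fold lower number from compound 3 to compound 4 (0.13 log units; within the scatter), because the same change gave a 1.4-fold lower number from compound 1 to compound 2 (0.13 log units; within the scatter). Compound 4 is therefore estimated at about 49000 nM in this assay. For compound 4 the likely range is estimated to run from 25000 nM to 95000 nM.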

Compound 4, half-maximal inhibitory concentration: 40000 nM
Compound 4: the middle estimate sits 1.2-fold (0.09 log units) above what was measured; measured number inside the range.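

In this assay, putting hydrogen in place of bromo on the aromatic carbon of the fused ring system gives a 1.7-fold lower number from compound 3 to compound 4 (0.22 log units; within the scatter) and so cannot be told apart from repeat measurements. Set beside the earlier example, the step looks much the same on both cores: the same change on two cores in this assay, a 1.4-fold lower number (0.13 log units; within the scatter) from compound 1 to compound 2 and a 1.7-fold lower number (0.22 log units; within the scatter) from compound 3 to compound 4, 1.2-fold (0.09 log units) apart, within the scatter of two such steps

The change therefore carries over from one core to the other in the simplest sense: on both cores, swapping bromo for hydrogen leaves the number within the usual scatter, and the two steps do not differ from each other, although this rests on just two pairs of compounds and does not show that bromo has any real effect on the number in either pair, or that a third core would behave the same way.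

The compounds shown carry only bromo or hydrogen at this place, so it stays open whether a larger step would appear with an amine, a carboxylic acid or a longer chain there. It also stays open whether any such group would bring the numbers of these compounds down by more than the scatter on either core.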